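This account rests on a few compounds, and the source may have more. Where it says the series, first, only, none or still open, it means among the compounds named here.

The measured compounds in a functional assay on NCI-H520 cells (Homo sapiens) for inhibition, read by MTT assay, with a stated time of 48 h, tested at 10 uM (a lower number here means less inhibition, a higher number more inhibition at the concentration tested (going by the name of the read-out)), are:
compound 1, `COc1cc(NC(=O)Nc2cc(Nc3cc(C)cc(F)c3)ncn2)cc(OC)c1`, with 24.5%;
compound 2, `COc1cc(NC(=O)Nc2cc(Nc3ccc(F)c(Cl)c3)ncn2)cc(OC)c1`, with 25.5%;
compound 3, `COc1cc(NC(=O)Nc2cc(Nc3cc(I)ccc3OC)ncn2)cc(OC)c1`, with 55%.

Compound 3 stands highest of the three. Its nearest neighbour is compound 2, and the step of a number 29.5 percentage points higher from compound 2 to compound 3 (beyond the scatter) is beyond the scatter; the step of a number 30.5 percentage points higher from compound 1 to compound 3 (beyond the scatter) is larger still. Between compounds 1 and 2 the step of a number 1 percentage points higher from compound 1 to compound 2 (within the scatter) lies within the scatter, so these two cannot be placed in order.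

Compound 4, `COc1cc(NC(=O)Nc2cc(Nc3ccc(C)c(C)c3)ncn2)cc(OC)c1`, has not yet been measured in this assay. It differs from compound 3 in one place: 3,4-dimethylphenyl in place of 5-iodo-2-methoxyphenyl on a nitrogen on an aromatic ring.

Among the measured compounds shown here, two measured steps bear on this change, since both lead into compound 3 by exchanging the group on that nitrogen: the step of a number 30.5 percentage points higher from compound 1 to compound 3 (beyond the scatter) and the step of a number 29.5 percentage points higher from compound 2 to compound 3 (beyond the scatter). Both were large gains on arriving at the 5-iodo-2-methoxyphenyl. Compound 4 gives up that group for a 3,4-dimethylphenyl, so a fall back towards the level of compounds 1 and 2 is expected, with the step of a number 27 percentage points lower from compound 3 to compound 4 (beyond the scatter) estimated as beyond the scatter. Compound 4 is therefore expected to give about 28%, within a range from 15% to 45%.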

Compound 4, a percentage reported as inhibition, at one concentration (the size of the read-out at that concentration, not a potency): 29.5%
Beside the measured number, compound 4's estimate is 1.5 percentage points below it; measured number inside the range.
By their numbers in this assay, from the lowest: compounds 1, 2 and 4 (each within the scatter of the next); then compound 3.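

In this assay, the step of a number 25.5 percentage points lower from compound 3 to compound 4 (beyond the scatter) shows that the level of compound 3 does not carry over to just any substituted phenyl on this nitrogen: a 3,4-dimethylphenyl, which has no oxygen or iodine, does not keep it. The steps of a number 4 percentage points higher from compound 2 to compound 4 (within the scatter) and a number 5 percentage points higher from compound 1 to compound 4 (within the scatter) cannot be told from scatter, so a phenyl with two methyl groups and no halogen cannot be placed in order against the 3-chloro-4-fluorophenyl or the 3-fluoro-5-methylphenyl, and among these four compounds only compound 3 stands apart. No measurement is at hand that would explain this difference.

The compounds shown do not tell whether the level of compound 3 goes with the iodine, with the methoxy group or only with the two together, since the 5-iodo-2-methoxyphenyl is the only group here that carries either. Going by these compounds, it also remains open how a phenyl bearing an amine or a carboxylic acid would read at this nitrogen, and whether the gap would persist with anything other than the dimethoxyphenyl end of the shared core.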